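From ethoxy to propoxy: compound 3 and compound 4

The compounds below may be only part of what the source reports. "The series", "measured", "known", "first", "only" and "open" are said of these compounds alone.

For the measured compounds named here, in a functional assay on 1A9 cells (Homo sapiens) for antiproliferative activity, read by sulforhodamine B assay, with a stated time of 3 days (a lower number here means that less compound is needed, a higher number that more compound is needed for the effect), compound 3 `CCCC1=C(OCC)C(CCC)(CCC)C(=O)/C(=C(O)\C=C\c2ccccc2)C1=O` gives 4.3 uM and is one of only two compounds with a number. Its nearest neighbour is compound 2 `CCCC1=C(OCC(C)C)C(CCC)(CCC)C(=O)/C(=C(O)\C=C\c2ccccc2)C1=O` at 6.9 uM (with no real gap), while compound 1 `CCCC1=C(OCCC(C)C)C(CCC)(CCC)C(=O)/C(=C(O)\C=C\c2ccccc2)C1=O` has the entry "not determined" (no result reported) and offers no number to compare. Going by the values given here, the only measured step (a 1.6-fold lower number from compound 2 to compound 3 (0.21 log units; within the scatter)) puts methyl in place of isopropyl on a saturated chain carbon bound to an oxygen, so the two values cannot be told apart.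

Compound 4 `CCCOC1=C(CCC)C(=O)/C(=C(O)/C=C/c2ccccc2)C(=O)C1(CCC)CCC` carries propoxy where compound 3 carries ethoxy, which means methyl in place of hydrogen on a saturated chain carbon, two bonds along the chain from an oxygen on an unsaturated carbon. Among the compounds with values here, the one step on this chain, from compound 2 (a 1.6-fold lower number from compound 2 to compound 3 (0.21 log units; within the scatter)), stayed within the scatter, so no step beyond the scatter is expected in this assay for this change, in either direction. The expected step is small (a 1.2-fold higher number from compound 3 to compound 4 (0.07 log units; within the scatter)). Compound 4 is estimated at 5 uM within an expected range from 2.7 uM to 9.5 uM (an expectation, not a measurement).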

Compound 4, concentration for half-maximal effect: 2 uM
Compound 4: middle estimate off by 2.5-fold (0.40 log units), on the high side, and the stated range ends above it.
By their numbers in this assay, from the lowest: compound 4; then compounds 3 and 2 (each within the scatter of the next).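

In this assay, for the compounds shown here, going from ethoxy to propoxy gives a 2.2-fold lower number from compound 3 to compound 4 (0.33 log units; beyond the scatter), so a methyl in place of hydrogen at this place on the chain produces a modest but real change, the first step here to pass beyond the scatter. The position also responds to branching: taking a methyl off the saturated chain carbon bound to two saturated chain carbons gives a 3.5-fold lower number from compound 2 to compound 4 (0.54 log units; beyond the scatter), so the unbranched propoxy of compound 4 needs less compound than the branched chain of compound 2. Nothing available explains why these changes lower the number.

A single propoxy result cannot show whether the number would keep falling with a longer chain such as butoxy or has already reached its lowest point. From the compounds shown here alone, it also remains open how this position would respond to an amine or a carboxylic acid at the end of the chain.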